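Trimming an Ether Chain on a Cytotoxic Core

This account rests on a few compounds, and the source may have more. Where it says the series, first, only, none or still open, it means among the compounds named here.

Of the compounds shown here, three have so far been tested in a functional assay on NCI-H1650 cells (Homo sapiens) for cytotoxicity, read by MTT assay, with a stated time of 48 h; a higher number here means a weaker inhibitor, a lower number a stronger inhibitor. Compound 1, with the structure `CC(C)COc1ccc2c(Cl)ccnc2c1`, gives 2100 nM. Compound 2, built as `C=CCOc1ccc2c(NCCN(C)C)ccnc2c1`, gives 930 nM, and compound 3, built as `CN(C)CCCNc1ccnc2cc(OCc3ccc(F)cc3)ccc12`, gives 940 nM. Compound 1 therefore stands at the highest of the three numbers, which makes it the weakest inhibitor of the set; compound 3 comes nearest, with a number lower by a margin beyond the usual scatter, and compound 2 sits furthest, with a gap of almost the same size. None of these three compounds differs from another in only one place, so no single structural step can be read directly from them.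

Compound 4, built as `CC(C)Oc1ccc2c(Cl)ccnc2c1`, is the next compound to enter this assay. It differs from compound 1 by isopropyl in place of isobutyl on an oxygen on an aromatic ring, with the shared core otherwise untouched. Among the compounds with values here, no measured pair isolates a change of this kind, so there is no measured step to lean on. The expectation is a step that stays within the usual scatter, in no clear direction, and the estimated step is a 1.1-fold higher number from compound 1 to compound 4 (0.06 log units; within the scatter). Compound 4 is expected to give about 2400 nM, with a plausible range from 1000 nM to 5500 nM.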

Compound 4, half-maximal inhibitory concentration: 2310 nM
Compound 4: the middle estimate sits 1.0-fold (0.02 log units) above what was measured, and the stated range covers the measured number.
By their numbers in this assay, from the lowest: compounds 2 and 3 (each within the scatter of the next); then compounds 1 and 4 (each within the scatter of the next).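

Within this assay compound 1 and compound 4 form the first pair that differs in one place only: isopropyl, with 3 heavy atoms, stands where isobutyl, with 4 heavy atoms, stood on the oxygen (a 1.1-fold higher number from compound 1 to compound 4 (0.04 log units; within the scatter)). That step lies within the usual scatter, so this read-out does not separate the isobutoxy and isopropoxy forms of the shared core. Compound 2 and compound 3 could not show this, since each differs from compound 1, from compound 4 and from one another in more than one place, which leaves those steps unreadable.

Still open, on these data alone, is whether a group further from these two on the same oxygen, such as a small methyl, a longer hexyl chain or a chain ending in an amine, would shift the number beyond the scatter, and whether the same isobutyl-to-isopropyl exchange would read alike on the cores of compound 2 and compound 3. Nothing measured here accounts for the close agreement between the two groups.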